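Dropping a benzyl group: what compound 4 may tolerate

The compounds below may be only part of what the source reports. "The series", "measured", "known", "first", "only" and "open" are said of these compounds alone.

Compound 1 `CCN(CC)C(=O)Oc1ccc(C(CC)(CC)c2ccc(NC(C)=O)c(C)c2)cc1C`: 50000 nM
Compound 2 `CC[Si](CC)(c1ccc(OCC(=O)C(C)(C)C)cc1)c1ccc(OCC(=O)C(C)(C)C)cc1`: > 100000 nM
Compound 3 `CCC(CC)(c1ccc(OCC(=O)C(C)(C)C)c(C)c1)c1ccc(N(CC(=O)C(C)(C)C)Cc2ccccc2)c(C)c1`: > 100000 nM

In an ADME assay on MDBK cells (Bos taurus) for cytotoxicity (a lower number here means that less compound is tolerated, a higher number that more compound is tolerated), compound 1 gives 50000 nM. For compound 2 the measurement reports only a limit, > 100000 nM. For compound 3 the result is likewise a limit, > 100000 nM, which is the limit of > 100000 nM in this assay, at which 2 of the 3 values shown sit. Among the measured compounds shown here, compound 3 therefore stands at the edge of what this assay can report, alongside compound 2, while compound 1 is the one compound with a number. Compound 4 `CCC(CC)(c1ccc(NCC(=O)C(C)(C)C)c(C)c1)c1ccc(OCC(=O)C(C)(C)C)c(C)c1` differs from compound 3 by hydrogen in place of benzyl on a nitrogen on an aromatic ring. For the measured compounds named here, no measured pair with a single change is available, so the expected step of a number no higher from compound 3 to compound 4 (the limit leaves the size open) in this assay is taken as none beyond the usual scatter. Compound 4 is estimated at 100000 nM, within a range from 30000 nM to 300000 nM, most likely again as a limit.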

Compound 4, half-maximal cytotoxic concentration: 82000 nM
Compound 4: middle estimate off by 1.2-fold (0.09 log units), on the high side; measured number inside the range.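

In this assay, among the compounds shown here, hydrogen in place of benzyl on a nitrogen on an aromatic ring gives an at least 1.2-fold lower number from compound 3 to compound 4 (0.08 log units; that floor lies within the scatter) and so a first reading of this change. Compound 4 returns a number at this position, and it shows that the compound stays well tolerated without the benzyl group. Compound 3 is reported only as a limit, and because of that the true size of the step cannot be read: the limit of > 100000 nM in this assay, at which 2 of the 4 values shown sit.

The compounds shown leave open how a methyl group or a longer chain ending in a carboxylic acid on this nitrogen would behave in this assay.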